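Amide aryl variation in a flavonol antiproliferative series

The source may hold more compounds than are shown below. What is called first, only, known or untested is meant among the compounds shown, and "the series" means these compounds.

Among the measured compounds shown here, compound 2 `COc1cccc(C(=O)Nc2cccc(-c3oc4cc(-c5ccc(F)cc5)ccc4c(=O)c3O)c2)c1` gives 10800 nM in a functional assay on A549 cells (Homo sapiens) for antiproliferative activity, read by CCK-8 assay, with a stated time of 72 h (on this read-out higher numbers stand for weaker inhibition and lower numbers for stronger inhibition), and so carries the highest of the two numbers recorded; its only neighbour is compound 1 `COc1ccc(C(=O)Nc2cccc(-c3oc4cc(-c5ccc(F)cc5)ccc4c(=O)c3O)c2)cc1`, which gives 8700 nM, and the step of a 1.2-fold higher number from compound 1 to compound 2 (0.09 log units; within the scatter) leaves the pair within the scatter. Compound 3 `COc1ccc(C(=O)Nc2cccc(-c3oc4cc(-c5ccc(F)cc5)ccc4c(=O)c3O)c2)c(F)c1` is the next analogue, with 2-fluoro-4-methoxyphenyl in place of 3-methoxyphenyl on a carbonyl carbon. For the measured compounds named here, the sole measured step bearing on this change is the one from compound 1 to compound 2, an exchange of methoxyphenyl isomers on the same carbonyl carbon, and it was small. Going by the values given here, compound 3 keeps the 4-methoxyphenyl of compound 1 with a fluorine added, and no measured pair shows what an added fluorine on this aryl group does. For this assay no step beyond the scatter is therefore expected, with a 1.2-fold lower number from compound 2 to compound 3 (0.08 log units; within the scatter) as the expected shift. Compound 3 is estimated at 9000 nM, within a range from 3500 nM to 25000 nM.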

Compound 3, half-maximal inhibitory concentration: 40000 nM
Estimate against measurement, compound 3: 4.4-fold (0.65 log units) below, outside the stated range (above it).
By their numbers in this assay, from the lowest: compounds 1 and 2 (each within the scatter of the next); then compound 3.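

In this assay, among the compounds shown here, this aryl group on the amide carbonyl proves sensitive to substitution: the two methoxyphenyl isomers lie within the scatter of each other, whereas fluoro in place of hydrogen on an aromatic carbon gives a 4.6-fold higher number from compound 1 to compound 3 (0.66 log units; beyond the scatter), the first step beyond the scatter, towards weaker inhibition. Against the 3-methoxyphenyl analogue, 2-fluoro-4-methoxyphenyl in place of 3-methoxyphenyl on the carbonyl carbon gives a 3.7-fold higher number from compound 2 to compound 3 (0.57 log units; beyond the scatter), a modest step in the same direction. Nothing available here explains the loss that accompanies the added fluorine.

Still open, as far as these compounds go, is whether this loss is specific to fluorine or would also follow a chloro or methyl group on this aryl ring. From the compounds shown here alone, the effect of an amine or a carboxylic acid on the same ring also remains open.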